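Pyrimidine for Fluorophenyl on a Weaker Amine Scaffold

The source may report more compounds than this note shows. Statements on the series, on what has been measured and on what is new or still open speak of the compounds shown alone.

Compound 1 `C[C@H](NC(=O)c1cccc(F)c1)c1ccc(NC(=O)N2CC(c3cccnc3)C2)cc1` is the reference point of this set. In a functional assay on COR-L23 cells (Homo sapiens) for antiproliferative activity, read by CellTiter-Glo, with a stated time of 72 h (a lower number here means a stronger inhibitor, a higher number a weaker inhibitor), compound 1 gives 10 nM. Compound 2 `C[C@H](NC(=O)c1ncccn1)c1ccc(NC(=O)N2CC(c3cccnc3)C2)cc1` differs from it in one place, (pyrimidin-2-yl in place of 3-fluorophenyl on a carbonyl carbon), and in this assay compound 2 gives 130 nM, so that a 13-fold higher number from compound 1 to compound 2 (1.11 log units; beyond the scatter). Compound 3 `C[C@H](NC(=O)c1cccc(F)c1)c1ccc(NC(=O)N2CC(c3cncc(N)c3)C2)cc1` carries a different single change from compound 1, (amino in place of hydrogen on an aromatic carbon). In this assay compound 3 gives 630 nM, and a 63-fold higher number from compound 1 to compound 3 (1.80 log units; beyond the scatter); compound 3 thus stands highest among the three measured numbers.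

Compound 4 `C[C@H](NC(=O)c1ncccn1)c1ccc(NC(=O)N2CC(c3cncc(N)c3)C2)cc1` has not yet been measured. It differs from compound 3 by pyrimidin-2-yl in place of 3-fluorophenyl on a carbonyl carbon, which is the same change that was already seen between compound 1 and compound 2, made here on the core of compound 3 rather than the core of compound 1. The two cores themselves differ by amino in place of hydrogen on an aromatic carbon.

Among the compounds with values here, the expected step from compound 3 to compound 4 is a 9.5-fold higher number from compound 3 to compound 4 (0.98 log units; beyond the scatter), which sits beside the measured 13-fold higher number from compound 1 to compound 2 (1.11 log units; beyond the scatter); the expectation rests on the assumption that the change behaves on the core of compound 3 about as it did from compound 1 to compound 2, a transfer supported by only that one measured pair. Compound 4 is therefore estimated at 6000 nM in this assay, with a range from 1500 nM to 20000 nM.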

Compound 4, half-maximal inhibitory concentration: 1380 nM
Estimate against measurement, compound 4: 4.3-fold (0.64 log units) above; the measured number lies below the stated range.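

Pyrimidin-2-yl in place of 3-fluorophenyl on a carbonyl carbon gives a higher number on both cores in this assay, so the direction of the change carries over, but on the core of compound 3 the step is only a 2.2-fold higher number from compound 3 to compound 4 (0.34 log units; beyond the scatter), and its size does not carry over: the same change on two cores in this assay, a 13-fold higher number (1.11 log units; beyond the scatter) from compound 1 to compound 2 and a 2.2-fold higher number (0.34 log units; beyond the scatter) from compound 3 to compound 4, 5.9-fold (0.77 log units) apart, beyond the scatter of two such steps

Read the other way round, amino in place of hydrogen on an aromatic carbon also gives a higher number when the pyrimidin-2-yl group is present, an 11-fold higher number from compound 2 to compound 4 (1.03 log units; beyond the scatter), yet this step differs in size from the one seen with the 3-fluorophenyl group: the same change on two cores in this assay, a 63-fold higher number (1.80 log units; beyond the scatter) from compound 1 to compound 3 and an 11-fold higher number (1.03 log units; beyond the scatter) from compound 2 to compound 4, 5.9-fold (0.77 log units) apart, beyond the scatter of two such steps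

The two changes therefore do not add independently in these four compounds, but a single set of four cannot show why they do not, nor whether the same holds on any other core.

As far as these compounds go, what remains open is whether a smaller step for the same change would also appear if a hydroxyl, methoxy or dimethylamino group stood in place of the amino group. From the compounds shown here alone, it is equally open whether another group on the carbonyl carbon, such as pyridin-2-yl or cyclopropyl, would follow the pyrimidin-2-yl group or behave differently on the two cores.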